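This account rests on a few compounds, and the source may have more. Where it says the series, first, only, none or still open, it means among the compounds named here.

Measured so far:
Compound 1, `CC(Cc1ccc(Cl)cc1)(Oc1ccc(Cc2ccccc2)cc1)C(=O)O`: in a functional assay on the whole organism for inhibition, with Rattus norvegicus as the target (a lower number here means that less compound is needed, a higher number that more compound is needed for the effect), compound 1 gives 1 mg/kg.
Compound 2, `CCc1ccc(CC(C)(Oc2ccc(Cc3ccccc3)cc2)C(=O)O)cc1`: in this assay compound 2 gives 1 mg/kg.
Compound 3, `CC(C)c1ccc(OC(C)(Cc2ccc(Cl)cc2)C(=O)NS(=O)(=O)C(F)(F)F)cc1`: in this assay compound 3 gives 5 mg/kg.

Compound 1 and compound 2 share a core and differ in one place, by ethyl in place of chloro on an aromatic carbon. This change made no change at the digits printed from compound 1 to compound 2 (within the scatter), so the two values sit together within the scatter of the measurement and no order between them can be read.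

Compound 3 is built on a different core; how its core differs from the core of compound 1 is not broken down here. Its value in this assay stands higher than those of compound 1 and of compound 2, and in both cases the gap lies beyond the scatter.

Compound 4, `CCc1ccc(CC(C)(Oc2ccc(C(C)C)cc2)C(=O)NS(=O)(=O)C(F)(F)F)cc1`, has not yet been measured. It differs from compound 3 by ethyl in place of chloro on an aromatic carbon. Among the measured compounds shown here, the place of the change is described in the same words for both pairs, so this is the same change as the one from compound 1 to compound 2, now made on the core of compound 3.

For compound 4 an essentially unchanged value is expected, that is a step of no change at the digits printed from compound 3 to compound 4 (within the scatter) from compound 3, because the same change on the other core gave no change at the digits printed from compound 1 to compound 2 (within the scatter). The estimate for compound 4 in this assay is therefore 5 mg/kg, expected to fall between 2 mg/kg and 12 mg/kg.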

Compound 4, dose for half-maximal effect: > 10 mg/kg
Compound 4: a limit, no number (the forecaster's own chance of this, stated with the estimate: 5%); middle value at least 2.0-fold (0.30 log units) from the limit.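

In this assay, compound 4 gives a limit of the assay and not a number: the limit of > 10 mg/kg in this assay, at which 1 of the 4 values shown sits. Exchanging chloro for ethyl on the core of compound 3 gives an at least 2.0-fold higher number from compound 3 to compound 4 (0.30 log units; that floor lies within the scatter), so the step has a lower bound only, and because that bound stays within the scatter, it does not establish a real rise on this core. The two steps can therefore be set side by side, but they neither show that the change carries over from one core to the other nor show that its outcome depends on the core: the same change on two cores in this assay, no change at the digits printed (within the scatter) from compound 1 to compound 2 and an at least 2.0-fold higher number (0.30 log units; that floor lies within the scatter) from compound 3 to compound 4; the limit leaves it open whether they differ.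

The compounds shown leave open how far the value of compound 4 lies beyond the limit, and so whether the change behaves on the core of compound 3 as it does on the core of compound 1. They also leave open what other groups would give in the place of chloro and ethyl, such as methyl, methoxy or a longer chain such as propyl, and whether any such exchange would give matching steps on both cores.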